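Replacing the fluorophenyl ring with a butyl chain

The compounds below may be only part of what the source reports. "The series", "measured", "known", "first", "only" and "open" are said of these compounds alone.

For the measured compounds named here, compound 3 `CN1CCC[C@@H]1Cn1nc(Cc2ccc(F)cc2)c2ccccc2c1=O` is one of three compounds measured in an assay for binding affinity to Alpha-1A adrenergic receptor (Homo sapiens); on this read-out higher numbers stand for weaker inhibition and lower numbers for stronger inhibition. Compound 3 gives 63.1 nM, the lowest number of the three. Compound 2 `CN1CCC[C@@H]1Cn1nc(CCc2ccccc2)c2ccccc2c1=O` gives 200 nM, and compound 1 `CN1CCC[C@@H]1Cn1nc(Cc2cccc(Cl)c2)c2ccccc2c1=O` gives 398 nM. The steps among them are all swaps of one aromatic group for another on the saturated chain carbon bound to an aromatic carbon: a 2.0-fold lower number from compound 1 to compound 2 (0.30 log units; within the scatter), a 6.3-fold lower number from compound 1 to compound 3 (0.80 log units; beyond the scatter) and a 3.2-fold lower number from compound 2 to compound 3 (0.50 log units; beyond the scatter).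

Compound 4 `CCCCCc1nn(C[C@H]2CCCN2C)c(=O)c2ccccc12` has not been measured. It differs from compound 3 in one place: butyl in place of 4-fluorophenyl on a saturated chain carbon bound to an aromatic carbon. Unlike the measured steps, this change removes the aromatic ring entirely and puts a chain with no ring in its place. Going by the values given here, none of the measured steps shows what happens when the ring is lost; they only show that changing the substituent on that ring moves the number by modest amounts. Since compound 3 stands at 63.1 nM and is the best of its small group, compound 4 is expected to give a higher number in this assay, with an estimated step of a 5.1-fold higher number from compound 3 to compound 4 (0.71 log units; beyond the scatter). The estimate for compound 4 in this assay is 320 nM, with a range from 80 nM to 1300 nM.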

Compound 4, inhibition constant: 501 nM
Compound 4: middle estimate off by 1.6-fold (0.19 log units), on the low side; low and high end bracket the measured number.
By their numbers in this assay, from the lowest: compound 3; then compounds 2, 1 and 4 (each within the scatter of the next, the first and the last beyond it).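

For the compounds shown here, replacing the 4-fluorophenyl ring with butyl is the first change here that leaves no ring on this side of the molecule, and in this assay it gives a 7.9-fold higher number from compound 3 to compound 4 (0.90 log units; beyond the scatter). Yet a ring at this place does not by itself secure a low number: butyl in place of 3-chlorophenyl gives a 1.3-fold higher number from compound 1 to compound 4 (0.10 log units; within the scatter), while propyl in place of phenyl, further along the chain, gives a 2.5-fold higher number from compound 2 to compound 4 (0.40 log units; beyond the scatter), so the ring-free chain matches one ring-bearing compound and falls behind the other two. Nothing available here explains why these rings differ from one another or from the open chain.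

The compounds shown leave open whether a saturated ring such as cyclohexyl, which keeps a ring but is not aromatic, would stay close to the 4-fluorophenyl compound or fall in with butyl. They also leave open how a shorter chain such as ethyl, a branched chain such as isobutyl, or a butyl chain ending in an amine or a hydroxyl group would read at this same place.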